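Benzoxazol-2-yl exchange on compound 1: cytotoxicity notes

A few compounds are considered here, and "the series" means these few. Any claim that something is new, unique, unknown or untested is made for them only; others in the source may bear on it.

Values in a functional assay on KB cells (Homo sapiens) for cytotoxicity, read by MTT assay, with a stated time of 48 h; a lower number here means a stronger inhibitor, a higher number a weaker inhibitor:
- compound 1 `CCn1cc(-c2nc3ccccc3[nH]2)c(=O)c2cc(F)c(N3CCNCC3)nc21`: 2000 nM
- compound 2 `CCn1cc(-c2nc3ccccc3o2)c(=O)c2cc(F)c(Cl)cc21`: 10200 nM

Compound 1 holds the lower of the two numbers, and the gap to compound 2 lies beyond the scatter. Compound 3 `CCn1cc(-c2nc3ccccc3o2)c(=O)c2cc(F)c(N3CCNCC3)nc21` puts 1,3-benzoxazol-2-yl in place of 1H-benzimidazol-2-yl on an aromatic carbon of the core of compound 1 (1,3-benzoxazol-2-yl in place of 1H-benzimidazol-2-yl on an aromatic carbon). Among the measured compounds shown here, no measured pair isolates this exchange. For the measured compounds named here, compound 2 also carries 1,3-benzoxazol-2-yl and gives 10200 nM, but it differs from compound 1 elsewhere too, so it fixes no step. The expected change is a 1.3-fold higher number from compound 1 to compound 3 (0.10 log units; within the scatter), which stays within the scatter. Compound 3 is estimated at 2500 nM, with an expected range of 700 nM to 9000 nM.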

Compound 3, half-maximal inhibitory concentration: 11700 nM
The estimate for compound 3 lay 4.7-fold (0.67 log units) below the measured number; the whole stated range lies below it.
By their numbers in this assay, from the lowest: compound 1; then compounds 2 and 3 (each within the scatter of the next).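

In this assay, 1,3-benzoxazol-2-yl in place of 1H-benzimidazol-2-yl on this aromatic carbon gives a 5.9-fold higher number from compound 1 to compound 3 (0.77 log units; beyond the scatter), so this position responds to the exchange. The two groups match in heavy-atom count and ring sizes, and they differ in one ring atom and in their hydrogen-bond donor and acceptor counts. Nothing measured here gives a reason for the step.

Still open, from the compounds shown here alone, is how an amine or a carboxylic acid on this aromatic carbon would compare with 1H-benzimidazol-2-yl. Also open, going by these compounds, is whether a longer chain in place of the ethyl group would change the size of this step.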